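Swapping Phenyl for Cyclohexyl on the Imine Nitrogen

The compounds below may be only part of what the source reports. "The series", "measured", "known", "first", "only" and "open" are said of these compounds alone.

Measured compounds:
compound 1, `CC1CC(=O)c2s/c(=N/c3ccccc3)oc2C1`, 2310 nM
compound 2, `CC(C)C1CC(=O)c2s/c(=N/c3ccccc3)oc2C1`, 2480 nM

In a functional assay on MDA-MB-231 cells (Homo sapiens) for antiproliferative activity, read by sulforhodamine B assay (on this read-out higher numbers stand for weaker inhibition of growth and lower numbers for stronger inhibition of growth), compound 1 gives 2310 nM. Compound 2, which carries an isopropyl in place of the methyl on a saturated ring carbon, gives 2480 nM. Among the measured compounds shown here, the only step measured so far, a 1.1-fold higher number from compound 1 to compound 2 (0.03 log units; within the scatter), is within the scatter, so compound 2 and compound 1 cannot be told apart on these numbers; compound 2 simply has the nearest neighbour in compound 1.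

Compound 3, `CC(C)C1CC(=O)c2s/c(=N/C3CCCCC3)oc2C1`, differs from compound 2 by cyclohexyl in place of phenyl on a double-bonded nitrogen. For the measured compounds named here, no measured step touches this position: the single step known, from compound 1 to compound 2, concerns the saturated ring carbon and not the double-bonded nitrogen. There is therefore no measured basis for expecting a change in either direction in this assay beyond the scatter, and the estimate for compound 3 must rest on the value of compound 2 alone, with a wide range to reflect that nothing is known about this exchange.

Compound 3 is expected to give about 2500 nM, in the range 800 nM to 8000 nM, which means an estimated step of a 1.0-fold higher number from compound 2 to compound 3 (0.00 log units; within the scatter).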

Compound 3, concentration for 50% growth inhibition: 5900 nM
Estimate against measurement, compound 3: 2.4-fold (0.37 log units) below, and the stated range covers the measured number.
By their numbers in this assay, from the lowest: compounds 1 and 2 (each within the scatter of the next); then compound 3.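

Among the compounds shown here, until now the only measured change lay on the saturated ring carbon, and it stayed within the scatter. For the compounds shown here, the double-bonded nitrogen is the first place where a change moves the number beyond the scatter in this assay, with cyclohexyl in place of phenyl giving a 2.4-fold higher number from compound 2 to compound 3 (0.38 log units; beyond the scatter), a modest step towards weaker inhibition of growth. The two groups have the same count of heavy atoms, all carbon, and the plain difference between them is that one six-membered ring is aromatic and the other is not, though nothing measured here explains why the number rises.

The compounds shown leave open how other groups on this nitrogen would behave, such as a pyridine ring, a benzyl group or an open butyl chain, any of which could move the number in either direction. They also leave open whether the exchange of phenyl for cyclohexyl would give a step of similar size with methyl rather than isopropyl on the saturated ring carbon.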